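Trimming the Dichlorophenyl of Compound 2 to Chlorophenyl

This account rests on a few compounds, and the source may have more. Where it says the series, first, only, none or still open, it means among the compounds named here.

Of the compounds shown here, two with a shared core have been measured so far. Compound 1 `COc1ccc(-c2cc(/C=C/C(=O)c3ccc(N)cc3)[nH]n2)cc1` carries a methoxyphenyl on one side and an aminophenyl ketone on the other; in a functional assay on MDA-MB-231 cells (Homo sapiens) for inhibition, read by MTT assay, with a stated time of 48 h (a lower number here means a stronger inhibitor, a higher number a weaker inhibitor), compound 1 gives 1700 nM. Compound 2 `COc1cc(-c2cc(/C=C/C(=O)c3ccc(Cl)c(Cl)c3)[nH]n2)cc(OC)c1OC` bears a trimethoxyphenyl and a 3,4-dichlorophenyl, and in this assay compound 2 gives 2100 nM. Within the data shown here, on the numbers at hand compound 2 is one of only two measured compounds, and its gap to compound 1 lies within the usual scatter, so neither can be called the stronger inhibitor.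

Compound 3 `COc1cc(-c2cc(/C=C/C(=O)c3ccc(Cl)cc3)[nH]n2)cc(OC)c1OC` has not yet been measured. It differs from compound 2 in one place: hydrogen in place of chloro on an aromatic carbon. Among the measured compounds shown here, with no measured pair showing what loss of a chloro does on this core, the expectation rests on compound 2 alone. He expects the step from compound 2 to compound 3 in this assay to be small, at most a modest rise that may not clear the scatter, so that a 1.3-fold higher number from compound 2 to compound 3 (0.12 log units; within the scatter) is anticipated. Compound 3 is therefore estimated at 2800 nM in this assay, within a range of 1200 nM to 6500 nM.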

Compound 3, half-maximal inhibitory concentration: 26000 nM
For compound 3 the middle estimate is 9.3-fold (0.97 log units) below the measured one, outside the stated range (above it).
By their numbers in this assay, from the lowest: compounds 1 and 2 (each within the scatter of the next); then compound 3.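

In this assay, among these compounds, the change from 3,4-dichlorophenyl to 4-chlorophenyl gives a 12-fold higher number from compound 2 to compound 3 (1.09 log units; beyond the scatter) and so lies beyond the scatter; this is the first step on the shared core that can be read in one place. It shows that on this six-membered aromatic ring of carbon only, the place ortho to a chloro group and meta to a large group does not take hydrogen in place of chloro without a large loss, even though the trimethoxyphenyl side stays the same and only one chlorine leaves. Nothing at hand explains why a single chlorine moves the number this far.

From the compounds shown here alone, whether bromo, fluoro, methyl or methoxy in that same place would keep the number of compound 3 from rising, or whether only chloro serves there, remains open, as does the effect of taking away the remaining chloro as well. Compound 1 differs from compound 2 and compound 3 in more than one place, so it cannot show whether an amino group on this ring would make up for the lost chloro.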